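A much longer chain on compound 1

The source may report more compounds than this note shows. Statements on the series, on what has been measured and on what is new or still open speak of the compounds shown alone.

In a functional assay on K562 cells (Homo sapiens) for cytotoxicity, read by MTT assay (on this read-out higher numbers stand for an effect only at larger amounts of compound and lower numbers for an effect already at smaller amounts), compound 1 (`CCCCCCCCCCCCC/C=C/[C@@H](O)[C@H](CO)n1cc(CCC)nn1`) gives 13000 nM and compound 2 (`CCCCCCCCCCCCCC[C@@H](O)[C@@H](O)[C@H](CO)n1cc(CCC)nn1`) gives 14900 nM within the usual scatter of it. For the measured compounds named here, compound 1 therefore stands level with the only other measured compound, and neither can be placed ahead of the other.

Compound 3 (`CCCCCCCCCCCCC/C=C/[C@@H](O)[C@H](CO)n1cc(CCCCCCCCCCCCC)nn1`) has not yet been measured. It differs from compound 1 by decyl in place of hydrogen on a saturated chain carbon, three bonds along the chain from an aromatic carbon and so carries decyl in place of hydrogen on a saturated chain carbon, three bonds along the chain from an aromatic carbon.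

Going by the values given here, no measured pair varies this chain, so the expectation rests on the size of the change alone and remains uncertain. A change this large is not expected to stay within the scatter, and the number is expected to rise, which would mean an effect only at larger amounts of compound. The expected move is a 2.3-fold higher number from compound 1 to compound 3 (0.36 log units; beyond the scatter) in this assay as a rough estimate. Compound 3 is expected to read 30000 nM in this assay (estimated range 8000 nM to 100000 nM).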

Compound 3, half-maximal effective concentration: > 50000 nM
Compound 3 was reported as a limit; the forecaster's own chance of this, stated with the estimate: 25%; middle value at least 1.6-fold (0.22 log units) away from the limit.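

For the compounds shown here, the earlier pair left this chain untouched, so compound 3 gives the first reading of this position: in this assay, decyl in place of hydrogen on a saturated chain carbon, three bonds along the chain from an aromatic carbon, gives an at least 3.8-fold higher number from compound 1 to compound 3 (0.58 log units; beyond the scatter). The position is therefore not indifferent to this change, and the much longer chain moves the number towards an effect only at larger amounts of compound, not towards smaller amounts. The value of compound 3, > 50000 nM, is a limit and not a number, so the step gives only the smallest possible size of the change: the limit of > 50000 nM in this assay, at which 1 of the 3 values shown sits.

With only these two chains compared at this place, the compounds shown do not tell how far the number of compound 3 really lies from that of compound 1, nor whether it climbs steadily with chain length or jumps at some length in between. They also leave open whether a shorter chain, or a chain ending in an amine or a carboxylic acid, would keep the number level with compound 1 or bring it lower.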